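The source may report more compounds than this note shows. Statements on the series, on what has been measured and on what is new or still open speak of the compounds shown alone.

Compound 3 has the structure `CCN1CCc2c(c(C(C)(C)C)nn2C(=O)Nc2ccc(F)cc2F)C1`. In a functional assay on the whole organism (strain Swiss albino) for inhibition, with Mus musculus as the target, in the formalin test, with stated times of 30 min and 5 min, at a dose of 100 mg/kg (a lower number here means less inhibition, a higher number more inhibition at the dose given (going by the name of the read-out)), compound 3 gives 4.4%, which stands second highest of the three numbers; its nearest neighbour is compound 1, whose structure is `CCN1CCc2c(c(C(C)(C)C)nn2C(=O)Nc2ccc(Br)cc2)C1` and which gives 0%, while the furthest is compound 2, with the structure `CCN1CCc2c(c(C(C)(C)C)nn2C(=O)Nc2c(C)cccc2C)C1`, which gives 15.7%. The measured steps set the frame: a number 4.4 percentage points higher from compound 1 to compound 3 (within the scatter), and a number 11.3 percentage points lower from compound 2 to compound 3 (beyond the scatter). The change under consideration is 2-fluoro-5-methylphenyl in place of 2,4-difluorophenyl on an amide-type nitrogen, giving compound 4 with the structure `CCN1CCc2c(c(C(C)(C)C)nn2C(=O)Nc2cc(C)ccc2F)C1`. For the measured compounds named here, no measured step brings a 2-fluoro-5-methylphenyl in; the closest guidance is that the ring carrying two methyl groups in compound 2 sits modestly above the rings carrying halogens in compounds 1 and 3. A change that keeps one fluorine and adds one methyl is therefore expected to give compound 4 at most a small rise, a number 4.6 percentage points higher from compound 3 to compound 4 (within the scatter), likely within the scatter. The estimate for compound 4 is 9%, with a range from 0% to 20%.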

Compound 4, a percentage reported as inhibition, in the whole organism at one dose (the size of the read-out at that dose, not a potency): 7%
The estimate for compound 4 lay 2 percentage points above the measured number; low and high end bracket the measured number.
By their numbers in this assay, from the lowest: compounds 1, 3, 4 and 2 (each within the scatter of the next, the first and the last beyond it).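

In this assay, 2-fluoro-5-methylphenyl in place of 2,4-difluorophenyl on the amide-type nitrogen reads as a number 2.6 percentage points higher from compound 3 to compound 4 (within the scatter), so this exchange of one fluorine for one methyl on the ring does not separate the two compounds. Compound 4 also stands within the scatter of both earlier compounds, at a number 8.7 percentage points lower from compound 2 to compound 4 (within the scatter) and a number 7 percentage points higher from compound 1 to compound 4 (within the scatter), although the step from compound 1 to compound 2 and the step from compound 2 to compound 3 are printed as beyond it, so the mixed ring cannot be placed with either the halogen rings or the dimethyl ring. No evidence is available that bears on this result.

The compounds shown leave open whether a methoxy group or a dimethylamino group on this phenyl ring would move the number beyond the scatter of these values. They also leave open what a benzyl group in place of the phenyl ring on the amide-type nitrogen would do.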